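The compounds below may be only part of what the source reports. "The series", "measured", "known", "first", "only" and "open" are said of these compounds alone.

Of the compounds shown here, three built on one shared core have been measured so far: compound 1 `Fc1ccc(-n2cc(COc3ccccc3-c3nc4ccccc4s3)nn2)cc1`, compound 2 `Brc1ccc(-c2cc(COc3ccccc3-c3nc4ccccc4s3)on2)cc1` and compound 3 `c1ccc(-n2cc(COc3ccccc3-c3nc4ccccc4s3)nn2)cc1`. In a functional assay on COLO 205 cells (Homo sapiens) for cytotoxicity, read by MTT assay, with a stated time of 24 h (on this read-out lower numbers stand for stronger inhibition and higher numbers for weaker inhibition), compound 1 gives 18900 nM, compound 2 gives 16400 nM, and compound 3 gives 16600 nM. The number for compound 3 sits close to those of the other two, nearest to compound 2 and a little further from compound 1, and both gaps are within the usual scatter, so none of the three can be called stronger or weaker than another. Among the measured compounds shown here, the one single-point change measured is a 1.1-fold lower number from compound 1 to compound 3 (0.06 log units; within the scatter), hydrogen in place of fluoro on an aromatic carbon, again within the scatter.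

The next compound, compound 4 `Fc1ccc(-n2cc(COc3ccccc3-c3nc4ccccc4s3)nn2)cc1Cl`, differs from compound 3 in one place: 3-chloro-4-fluorophenyl in place of phenyl on an aromatic nitrogen. For the measured compounds named here, the only measured step that bears on it is a 1.1-fold lower number from compound 1 to compound 3 (0.06 log units; within the scatter), which shows that a fluoro on that ring moves the number by nothing beyond the scatter. Going by the values given here, no measured pair speaks to the chloro. The expected step in this assay is therefore a 1.1-fold lower number from compound 3 to compound 4 (0.04 log units; within the scatter), that is, none beyond the scatter. Compound 4 is estimated to give 15000 nM, with a range from 6000 nM to 40000 nM.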

Compound 4, half-maximal inhibitory concentration: 14400 nM
Estimate against measurement, compound 4: 1.0-fold (0.02 log units) above, and the stated range covers the measured number.
By their numbers in this assay, from the lowest: compounds 4, 2, 3 and 1 (each within the scatter of the next).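

In this assay, placing 3-chloro-4-fluorophenyl instead of phenyl on the aromatic nitrogen of the five-membered ring gives a 1.2-fold lower number from compound 3 to compound 4 (0.06 log units; within the scatter), so a group of 8 heavy atoms in place of one of 6 changes nothing that can be told from ordinary repeat variation. Among the compounds shown here, the chloro is the piece that no earlier pair covered, and adding it to the fluorinated ring gives a 1.3-fold lower number from compound 1 to compound 4 (0.12 log units; within the scatter), again inside the scatter. Among compounds 1, 3 and 4, this position has therefore tolerated a fluoro, a chloro and the two together without a readable change in the number, and no accompanying measurement offers an explanation for that flat result.

As far as these compounds go, both halogens are small single-atom substituents, so it remains open whether an amine, a carboxylic acid or a longer chain on this ring would move the number beyond the scatter. From the compounds shown here alone, it is also open whether a change elsewhere on the shared core, away from this ring, would have a larger effect in this assay.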